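The source may hold more compounds than are shown below. What is called first, only, known or untested is meant among the compounds shown, and "the series" means these compounds.

Compound 1 `CCOc1ccccc1C(=O)N(NC(=O)c1ccc(CC)cc1)C(C)(C)C`: 2880 nM in an assay on cells for agonist activity at ecdysone receptor (Bombyx mori), read by a luciferase reporter, with a stated time of 24 h; on this read-out higher numbers stand for an effect only at larger amounts of compound and lower numbers for an effect already at smaller amounts
Compound 2 `CCCCCC(=O)N(NC(=O)c1ccc(CC)cc1)C(C)(C)C`: 2820 nM in this assay

Compound 2 sits together with compound 1 in this assay: the step of a 1.0-fold lower number from compound 1 to compound 2 (0.01 log units; within the scatter) is within the scatter, so the two numbers are not separated. Compound 3 `CCc1ccc(C(=O)NN(C(=O)CCC(C)C)C(C)(C)C)cc1` differs from compound 2 by isopropyl in place of propyl on a saturated chain carbon, two bonds along the chain from a carbonyl carbon. For the measured compounds named here, no measured step bears on branching of the acyl chain; the only step, a 1.0-fold lower number from compound 1 to compound 2 (0.01 log units; within the scatter), exchanges the whole acyl group and was flat. The change is therefore expected to give no step beyond the scatter in this assay, a 1.0-fold lower number from compound 2 to compound 3 (0.00 log units; within the scatter). Compound 3 is estimated at 2800 nM, within 1400 nM to 5600 nM.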

Compound 3, half-maximal effective concentration: 832 nM
Beside the measured number, compound 3's estimate is 3.4-fold (0.53 log units) above it; the measured number lies below the stated range.
By their numbers in this assay, from the lowest: compound 3; then compounds 2 and 1 (each within the scatter of the next).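

In this assay, rearranging the same atoms at this position separates two compounds (a 3.4-fold lower number from compound 2 to compound 3 (0.53 log units; beyond the scatter)), so the acyl chain is not insensitive to change, as the flat earlier step (a 1.0-fold lower number from compound 1 to compound 2 (0.01 log units; within the scatter)) might have suggested. The isopentyl group also stands clear of 2-ethoxyphenyl on the carbonyl carbon (a 3.5-fold lower number from compound 1 to compound 3 (0.54 log units; beyond the scatter)). Nothing available accounts for the effect of this branching.

On these data alone, whether a cyclopentyl group in this place extends the step remains open. So does whether a longer chain with the same terminal isopropyl keeps it.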